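This account rests on a few compounds, and the source may have more. Where it says the series, first, only, none or still open, it means among the compounds named here.

Three compounds of one shared core have so far been examined in a functional assay, with a stated time of 150 min, tested at 30 ug/mL; on this read-out lower numbers stand for a weaker effect and higher numbers for a stronger effect at the one concentration tested. Compound 1, with the structure `Cc1ccc(C(=O)c2sc(Nc3ccccc3)c(C(=O)O)c2C)cc1`, is the only one of them to return a number: in this assay compound 1 gives 5.13%. Compound 2, with the structure `Cc1ccc(Nc2sc(C(=O)c3ccc(C)cc3)c(C)c2C(=O)O)cc1`, is reported in this assay as "not active" (no number reported), with no number behind it. Within the data shown here, compound 3, with the structure `Cc1ccc(C(=O)c2sc(Nc3ccc(F)cc3)c(C(=O)O)c2C)cc1`, stands in the same way: in this assay compound 3 is reported as "not active" (no number reported), again without a number, so compound 3 and compound 2 are the two entries that carry no single value, while the only value shown at all, that of compound 1, is itself small.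

Compound 4, with the structure `Cc1ccc(C(=O)c2sc(Nc3ccc(Cl)cc3)c(C(=O)O)c2C)cc1`, has not yet been measured in this assay. Its difference from compound 3 is chloro in place of fluoro on an aromatic carbon. Among the measured compounds shown here, since no step between measured compounds is available to calibrate this change, and the only value in the whole set is small, the step from compound 3 to compound 4 in this assay is expected to be no larger than the scatter, in no particular direction. Compound 4 is therefore estimated to give 4% in this assay, with a range from 0% to 14%, and it may well be reported without a number, as compound 3 was.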

Compound 4, a percentage reported as activity, at one concentration (the size of the read-out at that concentration, not a potency): "not active" (no number reported)
The entry for compound 4 holds no number; there is nothing to compare the estimate with.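

Among these compounds, compound 3 and compound 4 are both reported as "not active" in this assay, with no number behind either, so no step between them can be read. Nothing shown bears on this result. The compounds shown leave open whether chloro in place of fluoro changes this read-out at all.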